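Flipping One Ring Stereocentre in a Peroxide Acid

The compounds below may be only part of what the source reports. "The series", "measured", "known", "first", "only" and "open" are said of these compounds alone.

Measured compounds:
compound 1 `C=C1CCC[C@H]2[C@](C)(CC[C@]3(C)CC[C@@H]([C@@H](C)C(=O)O)OO3)[C@@H](C)CC[C@]12C` — 950 nM
compound 2 `CC1=C(CC/C(C)=C/CC[C@@]2(C)CC[C@@H]([C@H](C)C(=O)O)OO2)C(C)(C)CCC1` — only a limit, > 100000 nM
compound 3 `C=C1CCCC(C)(C)C1CC[C@@]1(C)CC[C@H]([C@@H](C)C(=O)O)OO1` — 4820 nM

These three compounds share a cyclic peroxide acid and were tested in a functional assay on KM12 cells (Homo sapiens) for inhibition; a lower number here means a stronger inhibitor of growth, a higher number a weaker inhibitor of growth. Compound 1 gives 950 nM and compound 3 gives 4820 nM. Compound 2 stands apart: in this assay it gives only a limit, > 100000 nM, so no number is known for it, and the limit of > 100000 nM in this assay, at which 1 of the 3 values shown sits, marks where it sits among the three values.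

Compound 4 `CC1=C(CC/C(C)=C/CC[C@@]2(C)CC[C@H]([C@H](C)C(=O)O)OO2)C(C)(C)CCC1` is the next compound to be measured. Set against compound 2 the difference is the two compounds have the same atoms and bonds and differ only in configuration as drawn: 1 of 4 stereo elements differ; a stereocentre at a saturated ring carbon is drawn S in compound 2 and R in compound 4. Since compound 2 has only a limit, the size of the step from compound 2 to compound 4 cannot be read from a measured pair; the other two compounds carry a cyclic tail that compound 4 lacks, so little guidance comes from them. Compound 4 is expected to remain a weak inhibitor, with an expected step of an at least 1.6-fold lower number from compound 2 to compound 4 (0.22 log units; that floor lies within the scatter). The estimate for compound 4 in this assay is 60000 nM, expected between 10000 nM and 200000 nM.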

Compound 4, concentration for 50% growth inhibition: > 5000 nM
Compound 4: no number, only a limit; the forecaster's own chance of this, stated with the estimate: 50%; the middle value does not contradict the limit.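

Compound 4 gives only a limit (> 5000 nM). Among the compounds shown here, compound 2 also has only a limit, and no step between these two compounds can be read. As far as these compounds go, whether changing this one ring stereocentre alters growth inhibition at all, and by how much, remains open.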